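Working notes: one aryl swap from compound 2

The source may hold more compounds than are shown below. What is called first, only, known or untested is meant among the compounds shown, and "the series" means these compounds.

Measured so far:
Compound 1 `O=[N+]([O-])c1cn2c(n1)OC(COc1ccc(-c3ccc(F)nc3F)cn1)CC2`: > 64000 nM (a limit)
Compound 2 `CC1(COc2ccc(-c3ccc(F)cc3F)cn2)CCn2cc([N+](=O)[O-])nc2O1`: > 64000 nM (a limit)

In an ADME assay on MRC5 cells (Homo sapiens) for cytotoxicity, read by resazurin assay, with a stated time of 72 h (a higher number here means a weaker inhibitor, a lower number a stronger inhibitor), compound 2 stands at > 64000 nM, which is a limit and not a number. Compound 1 gives > 64000 nM, which is also a limit. Among the measured compounds shown here, the series so far therefore amounts to the limit of > 64000 nM in this assay, at which 2 of the 2 values shown sit, and it offers no measured step between compounds.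

The next compound is compound 3 `CC1(COc2ccc(-c3ccc(F)nc3F)cn2)CCn2cc([N+](=O)[O-])nc2O1`. It differs from compound 2 in one place: 2,6-difluoropyridin-3-yl in place of 2,4-difluorophenyl on an aromatic carbon. The 2,6-difluoropyridin-3-yl group takes the place of 2,4-difluorophenyl on an aromatic carbon, para to a large group.

For the measured compounds named here, with no measured step to draw on, no change beyond the usual scatter is expected in this assay. That expectation rests only on compound 2 at > 64000 nM. A report of a limit, rather than a number, is the expected outcome for compound 3. The estimated size of the change is a number no higher from compound 2 to compound 3 (the limit leaves the size open). For compound 3 the expected value is 64000 nM, with an estimated range from 32000 nM to 128000 nM.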

Compound 3, half-maximal inhibitory concentration: > 64000 nM
Compound 3 ended at the assay's limit (the forecaster's own chance of this, stated with the estimate: 85%); the middle value sits exactly at the limit.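

In this assay, no step can be read from compound 2 to compound 3 or from compound 1 to compound 3, because all three values are limits and not numbers: the limit of > 64000 nM in this assay, at which 3 of the 3 values shown sit.

The compounds shown leave open whether either change, the 2,6-difluoropyridin-3-yl for 2,4-difluorophenyl or the methyl for hydrogen, shifts the value in this assay at all.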